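Cutting the 4-fluorobenzyl ether down to an ethyl ether

A few compounds are considered here, and "the series" means these few. Any claim that something is new, unique, unknown or untested is made for them only; others in the source may bear on it.

Of the compounds shown here, three sharing one core have been measured in a functional assay on DLD-1 cells (Homo sapiens) for cytotoxicity, read by MTT assay, with a stated time of 48 h; a higher number here means a weaker inhibitor, a lower number a stronger inhibitor. Compound 1 `CN(C)CCNc1ccnc2cc(OCc3ccc(F)cc3)ccc12` gives 810 nM. Compound 2 `CN(C)CCCNc1ccnc2cc(OCc3ccc(F)cc3)ccc12` gives 2540 nM, and compound 3 `Fc1ccc(COc2ccc3c(Cl)ccnc3c2)cc1` gives 3230 nM. Compound 2 stands second highest of the three: against compound 3 the difference is a 1.3-fold higher number from compound 2 to compound 3 (0.10 log units; within the scatter), while against compound 1 it is a 3.1-fold higher number from compound 1 to compound 2 (0.50 log units; beyond the scatter). The step of a 4.0-fold higher number from compound 1 to compound 3 (0.60 log units; beyond the scatter) completes the picture; all three measured steps concern the amine side chain or its replacement by chloro.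

Compound 4 `CCOc1ccc2c(NCCCN(C)C)ccnc2c1` is the unmeasured member. The change from compound 2 to compound 4 is methyl in place of 4-fluorophenyl on a saturated chain carbon bound to an oxygen on an aromatic ring. Among the measured compounds shown here, none of the measured steps touches this part of the molecule, so no measured step bears on it, and the expectation rests on the structural change alone.

Her estimate for compound 4 in this assay is 6000 nM, within a wide range from 1500 nM to 25000 nM. The step this implies, a 2.4-fold higher number from compound 2 to compound 4 (0.37 log units; beyond the scatter), is expected to lean toward a higher number, though it might equally fall within the scatter.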

Compound 4, half-maximal inhibitory concentration: 8540 nM
For compound 4 the middle estimate is 1.4-fold (0.15 log units) below the measured one; the range from low to high includes it.
By their numbers in this assay, from the lowest: compound 1; then compounds 2 and 3 (each within the scatter of the next); then compound 4.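

In this assay, among the compounds shown here, the step of a 3.4-fold higher number from compound 2 to compound 4 (0.53 log units; beyond the scatter) is the first measured change at the ether end of the molecule, and it shows that this end, not only the amine side chain, moves the number. In this single pair, with the (3-(dimethylamino)propyl)amino chain held constant, the 4-fluorobenzyl ether goes with the lower number and the ethyl ether with the higher one. Nothing shown here accounts for this difference.

As far as these compounds go, whether a benzyl ether without the fluorine would keep the lower number, or a propyl ether would fall between the two, remains open. So does whether cutting 4-fluorobenzyl to ethyl on the (2-(dimethylamino)ethyl)amino chain of compound 1 would give a step of similar size.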